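Notes on compound 4: expected clearance from compound 1

A few compounds are considered here, and "the series" means these few. Any claim that something is new, unique, unknown or untested is made for them only; others in the source may bear on it.

Compound 1 `CN(c1ncco1)c1cnc(NCc2c(F)ccc3c2CCO3)n2cnnc12` gives the lowest of the three numbers in an ADME assay on microsomes from liver (Homo sapiens) for metabolic stability, read by LC-MS, using NADPH, with stated times of 5 min and 30 min, tested at 1 uM (on this read-out lower numbers stand for slow clearance and higher numbers for fast clearance), at 11 mL.min-1.g-1. Compound 2 `Cc1nc(CN(C)C)ccc1-c1cnc(NCc2c(F)ccc3c2CCO3)c2cn[nH]c(=O)c12` gives 13 mL.min-1.g-1 in this assay, within the scatter of compound 1; compound 3 `Cc1cc(-c2cnc(NCc3c(F)ccc4c3CCO4)c3cn[nH]c(=O)c23)n(C)n1` gives 24 mL.min-1.g-1, beyond the scatter of compound 1. For the measured compounds named here, the only measured step is a 1.8-fold higher number from compound 2 to compound 3 (0.27 log units; within the scatter), made on a different core and at a different position, so it does not bear on the change at hand. Compound 4 `O=C(Nc1cnc(NCc2c(F)ccc3c2CCO3)n2cnnc12)c1cccnc1` carries ((pyridin-3-yl)carbonyl)amino in place of methyl(1,3-oxazol-2-yl)amino on an aromatic carbon. Going by the values given here, with no step touching this position, no shift beyond the scatter is expected. Compound 4 is estimated at 14 mL.min-1.g-1 in this assay, with a range of 6 mL.min-1.g-1 to 32 mL.min-1.g-1. The expected step is a 1.3-fold higher number from compound 1 to compound 4 (0.10 log units; within the scatter).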

Compound 4, intrinsic clearance in microsomes: < 3 mL.min-1.g-1
Compound 4 ended at the assay's limit; the forecaster's own chance of this, stated with the estimate: 5%; middle value at least 4.6-fold (0.66 log units) from the limit.
By their numbers in this assay, from the lowest: compounds 1, 2 and 3 (each within the scatter of the next, the first and the last beyond it). At a limit, below all of these: compound 4.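

In this assay, ((pyridin-3-yl)carbonyl)amino in place of methyl(1,3-oxazol-2-yl)amino on the same core gives an at least 3.6-fold lower number from compound 1 to compound 4 (0.56 log units; beyond the scatter). For the compounds shown here, the earlier compounds held no step at this position, and this is the first sign that the group on it can move this read-out beyond the scatter. Compound 4 stands at a limit of the assay, not at a number: the limit of < 3 mL.min-1.g-1 in this assay, at which 1 of the 4 values shown sits.

Which part of the entering group goes with the step stays open: the amide hydrogen, the carbonyl or the pyridine ring. A plain amine or an acetylamino group at this position would help to separate these.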